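From butyl to 1-methoxy-1-methylethyl: an open step

The source may report more compounds than this note shows. Statements on the series, on what has been measured and on what is new or still open speak of the compounds shown alone.

- Compound 1 `CC(C)(C)[C@@H](O)C(=O)N1C[C@@H]2C[C@@H]2[C@H]1C(=O)NCc1cc(Cl)ccc1-n1cnnn1`: < 15 mL.min-1.g-1
- Compound 2 `CCCC[C@@H](O)C(=O)N1C[C@H]2C[C@H]2[C@H]1C(=O)NCc1cc(Cl)ccc1-n1cnnn1`: 32 mL.min-1.g-1

Both compounds were measured in an ADME assay on liver for metabolic stability, with Liver microsome (Homo sapiens) as the target, read by LC-MS, using microsomes; a lower number here means slower removal, a higher number faster removal of the compound. The entry for compound 1 is a limit of the assay, not a number. For the measured compounds named here, that leaves compound 2 with the only actual number, 32 mL.min-1.g-1. Compound 3 `COC(C)(C)[C@@H](O)C(=O)N1C[C@H]2C[C@H]2[C@H]1C(=O)NCc1cc(Cl)ccc1-n1cnnn1` is not yet measured. It differs from compound 2 as follows: 1-methoxy-1-methylethyl in place of butyl on a saturated chain carbon bound to a carbonyl carbon and an oxygen on a saturated carbon. In words, 1-methoxy-1-methylethyl stands in place of butyl on a saturated chain carbon bound to a carbonyl carbon and an oxygen on a saturated carbon. Going by the values given here, no measured pair isolates this change, so the expectation is loose: a downward step in this assay, about as large as the usual scatter. The expected change is a 2.0-fold lower number from compound 2 to compound 3 (0.30 log units; within the scatter). Compound 3 is expected at 16 mL.min-1.g-1, with an estimated range of 8 mL.min-1.g-1 to 30 mL.min-1.g-1.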

Compound 3, intrinsic clearance in microsomes: 23 mL.min-1.g-1
The estimate for compound 3 lay 1.4-fold (0.16 log units) below the measured number, and the stated range covers the measured number.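

For the compounds shown here, at this position, on a saturated chain carbon bound to a carbonyl carbon and an oxygen on a saturated carbon, this assay now gives a first measured step for 1-methoxy-1-methylethyl in place of butyl: a 1.4-fold lower number from compound 2 to compound 3 (0.14 log units; within the scatter). The exchange, which brings in an oxygen and a hydrogen-bond acceptor, therefore does not separate the two compounds beyond the scatter. The entry for compound 1 is a limit of the assay and cannot be set against this step: the limit of < 15 mL.min-1.g-1 in this assay, at which 1 of the 3 values shown sits. As far as these compounds go, whether an amine or a longer chain at this place would give a step beyond the scatter remains open.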